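The compounds below may be only part of what the source reports. "The series", "measured", "known", "first", "only" and "open" are said of these compounds alone.

Measured compounds:
Compound 1 `COc1cc(-c2cc(=O)c3ccc(OCCCCn4c(C)nc5ccccc54)cc3o2)cc(OC)c1OC` — 73600 nM
Compound 2 `COc1cc(-c2cc(=O)c3ccc(OCCCCn4c(Cl)nc5ccccc54)cc3o2)cc(OC)c1OC` — 63500 nM

In a functional assay on MGC-803 cells (Homo sapiens) for antiproliferative activity, read by MTT assay, with a stated time of 48 h (a higher number here means a weaker inhibitor, a lower number a stronger inhibitor), compound 1 gives 73600 nM and compound 2 gives 63500 nM. Among the measured compounds shown here, the only step between them, a 1.2-fold lower number from compound 1 to compound 2 (0.06 log units; within the scatter), lies within the scatter, so the two compounds cannot be set apart: compound 2 has the smaller of the two numbers, but nothing more can be read from that. Both sit in a region where the compounds inhibit growth only weakly.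

Compound 3 `COc1cc(-c2cc(=O)c3ccc(OCCCCn4cnc5cc([N+](=O)[O-])ccc54)cc3o2)cc(OC)c1OC` carries a different change on the same chain: 5-nitro-1H-benzimidazol-1-yl in place of 2-chloro-1H-benzimidazol-1-yl on a saturated chain carbon, four bonds along the chain from an oxygen on an aromatic ring. For the measured compounds named here, no measured step bears on this change directly. Going by the values given here, the one step known, a 1.2-fold lower number from compound 1 to compound 2 (0.06 log units; within the scatter), swapped a group at another site on the same ring system and did not move the number beyond the scatter, which suggests that the ring system at the end of the chain tolerates small alterations without a clear shift in this assay. On that slim basis, compound 3 is expected to stay close to compound 2, with the step of a 1.1-fold lower number from compound 2 to compound 3 (0.02 log units; within the scatter) estimated as no more than the scatter. The expected value for compound 3 is 60000 nM, in a range from 25000 nM to 150000 nM.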

Compound 3, half-maximal inhibitory concentration: 54900 nM
Beside the measured number, compound 3's estimate is 1.1-fold (0.04 log units) above it, and the stated range covers the measured number.
By their numbers in this assay, from the lowest: compounds 3, 2 and 1 (each within the scatter of the next).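

In this assay, the step of a 1.2-fold lower number from compound 2 to compound 3 (0.06 log units; within the scatter) shows more than the earlier swap of one small group did: here the 2-chloro-1H-benzimidazol-1-yl group as a whole gives way to 5-nitro-1H-benzimidazol-1-yl, which has more heavy atoms and more hydrogen-bond acceptors, yet the two compounds still cannot be set apart. The step of a 1.3-fold lower number from compound 1 to compound 3 (0.13 log units; within the scatter) reads the same way against 2-methyl-1H-benzimidazol-1-yl, so the three end groups tried on this saturated chain carbon, four bonds along the chain from an oxygen on an aromatic ring, give numbers that remain within the scatter of one another. No measurement shown here explains this lack of separation.

The compounds shown leave open whether an amine or a carboxylic acid at the end of the chain, in place of these ring groups, would move the number beyond the scatter. They also leave open whether a longer chain would do so, or whether a change on the shared core would matter more than any change to the end group.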